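The source may report more compounds than this note shows. Statements on the series, on what has been measured and on what is new or still open speak of the compounds shown alone.

Working notes on the series. Compound 3 `Cn1c(-c2ccc(NC(=O)CSC3=NCCS3)cc2)nc(-c2ccccc2)c1-c1ccccc1` stands lowest of the three measured compounds in a functional assay on HT-29 cells (Homo sapiens) for cytotoxicity, read by MTT assay, with a stated time of 24 h, tested at 1.6 ug/mL (a lower number here means a weaker effect, a higher number a stronger effect of the compound at the concentration tested), where compound 3 gives 30.4%. Compound 1 `Cn1cnnc1SCC(=O)Nc1ccc(-c2nc(-c3ccccc3)c(-c3ccccc3)n2C)cc1` gives 40.8% and compound 2 `Cn1nnnc1SCC(=O)Nc1ccc(-c2nc(-c3ccccc3)c(-c3ccccc3)n2C)cc1` gives 49.8%; the steps of a number 10.4 percentage points lower from compound 1 to compound 3 (beyond the scatter) and a number 19.4 percentage points lower from compound 2 to compound 3 (beyond the scatter) are both beyond the scatter, while the step of a number 9 percentage points higher from compound 1 to compound 2 (within the scatter) is not.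

Compound 4 `Cn1c(-c2ccc(NC(=O)CN3CCN(c4ccccc4)CC3)cc2)nc(-c2ccccc2)c1-c1ccccc1` differs from compound 3 by a group of 12 heavy atoms (10 carbon, 2 nitrogen; one six-membered non-aromatic ring with 2 hetero atoms, one six-membered aromatic ring of carbon only) in place of a group of 6 heavy atoms (3 carbon, 1 nitrogen, 2 sulfur; one five-membered non-aromatic ring with 2 hetero atoms), on a saturated chain carbon bound to a carbonyl carbon. Among the measured compounds shown here, no measured step bears on this change: every measured step swaps the group on the sulfur, whereas here the sulfur-bearing group itself leaves and a phenylpiperazine enters. The direction is therefore open; a step of a number 9.6 percentage points higher from compound 3 to compound 4 (within the scatter) is expected only as a return toward the middle of the series.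

Compound 4 is estimated at 40%, within 22% to 58%.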

Compound 4, a percentage reported as activity, at one concentration (the size of the read-out at that concentration, not a potency): 26%
Estimate against measurement, compound 4: 14 percentage points above; the range from low to high includes it.
By their numbers in this assay, from the lowest: compounds 4 and 3 (each within the scatter of the next); then compounds 1 and 2 (each within the scatter of the next).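

In this assay, 4-phenylpiperazin-1-yl on the saturated chain carbon bound to a carbonyl carbon gives a read-out level with the cyclic sulfur group, the step being a number 4.4 percentage points lower from compound 3 to compound 4 (within the scatter). Against the two aromatic sulfanyl groups the same place does respond, with a number 14.8 percentage points lower from compound 1 to compound 4 (beyond the scatter) and a number 23.8 percentage points lower from compound 2 to compound 4 (beyond the scatter), so a link through sulfur is not needed for a read-out at the level of compound 3. Nothing at hand explains these steps.

Open, going by these compounds, is whether a smaller group here, such as morpholine or 4-methylpiperazin-1-yl, falls with compound 3 and compound 4. On these data alone, a carboxylic acid in this place is equally open.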